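The compounds below may be only part of what the source reports. "The series", "measured", "known", "first", "only" and "open" are said of these compounds alone.

Of the compounds shown here, three have numbers so far in an ADME assay on PC-12 cells (Rattus norvegicus) for cytotoxicity, read by MTT assay, with a stated time of 24 h; a lower number here means that less compound is tolerated, a higher number that more compound is tolerated. Compound 1 (`COc1ccc(N2CCN(CC#CCOC(=O)c3sc4ncnc(N5CCCCC5)c4c3C)CC2)cc1`) gives 140 ug/mL, and compound 2 (`COc1cccc(N2CCN(CC#CCOC(=O)c3sc4ncnc(N5CCCCC5)c4c3C)CC2)c1`) gives 144 ug/mL. Compound 3 (`Cc1ccc(-c2nnc(-c3sc4ncnc(N5CCCCC5)c4c3C)o2)cc1`) gives 161 ug/mL, which lies within the scatter of both other values.

Compound 4 (`Cc1c(-c2nnc(-c3ccc([N+](=O)[O-])cc3)o2)sc2ncnc(N3CCCCC3)c12`) differs from compound 3 by a single change: nitro in place of methyl on an aromatic carbon. In words, this is nitro in place of methyl on an aromatic carbon, or 4-methylphenyl to 4-nitrophenyl.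

Among the measured compounds shown here, the only measured step is a 1.0-fold higher number from compound 1 to compound 2 (0.01 log units; within the scatter), for 3-methoxyphenyl in place of 4-methoxyphenyl on an amine nitrogen in a ring. For the measured compounds named here, it lies within the scatter and bears only loosely on this change, since no measured pair involves nitro or methyl. The values of compounds 1, 2 and 3 also stay within the scatter despite their different groups on the shared core. No step beyond the scatter is therefore expected, and no direction can be assigned.

The expected step is a 1.1-fold lower number from compound 3 to compound 4 (0.03 log units; within the scatter). Compound 4 is estimated at 150 ug/mL, with an expected range from 85 ug/mL to 235 ug/mL.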

Compound 4, half-maximal cytotoxic concentration: 145 ug/mL
Beside the measured number, compound 4's estimate is 1.0-fold (0.01 log units) above it; the range from low to high includes it.
By their numbers in this assay, from the lowest: compounds 1, 2, 4 and 3 (each within the scatter of the next).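

On the aromatic carbon para to a large group, nitro in place of methyl gives a 1.1-fold lower number from compound 3 to compound 4 (0.05 log units; within the scatter) in this assay. Nitro enters with 3 heavy atoms and 2 hydrogen-bond acceptors where methyl had 1 heavy atom and 0 acceptors, yet compound 3 and compound 4 cannot be told apart in this read-out. Nothing available gives a measured property of either group or an explanation for this result.

Still open, going by these compounds, is whether any group on this carbon moves the number beyond the scatter: an amine or a carboxylic acid in the same place would test that in this assay. Also open, on these data alone, is whether a longer chain there would stay as close to compound 3 as nitro does.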